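The compounds below may be only part of what the source reports. "The series", "measured", "known", "first", "only" and "open" are said of these compounds alone.

Compound 1 `CS(=O)(=O)c1ccc(-c2oc3ccccc3c(=S)c2-c2ccc(F)cc2)cc1` was tested in an assay on isolated protein for inhibition of prostaglandin G/H synthase 1 (Mus musculus), tested at 10 ug/mL; on this read-out higher numbers stand for more inhibition at the one concentration tested (going by the name of the read-out) and lower numbers for less inhibition. In that assay compound 1 gives < 5%, which is a limit of the assay rather than a measured number. Two related compounds were run alongside it. Compound 2 `Cn1cc(-c2c(-c3ccc(S(C)(=O)=O)cc3)oc3ccccc3c2=O)cn1` gives < 5% in this assay, again a limit. Compound 3 `CS(=O)(=O)c1ccc(-c2oc3ccccc3c(=O)c2-c2cc(Cl)cc(Cl)c2)cc1` gives < 5%, also a limit. The step that the two limits leave unreadable from compound 2 to compound 3 therefore cannot be read, since (the limit of < 5% in this assay, at which 3 of the 3 values shown sit).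

Compound 4 `CS(=O)(=O)c1ccc(-c2oc3ccccc3c(=S)c2-c2ccc(Cl)c(Cl)c2)cc1` has not yet been measured. It differs from compound 1 in one place: 3,4-dichlorophenyl in place of 4-fluorophenyl on an aromatic carbon. Among the compounds with values here, no measured step covers this exchange; the only recorded step swaps a different group and its size is hidden by the limits. With every value shown sitting at the limit, nothing points towards a gain in inhibition, and the expectation is that the step that the limit leaves unreadable from compound 1 to compound 4 stays within the scatter. Compound 4 is therefore estimated to give 3% in this assay, within the range 0% to 12%, and most likely to be reported again only as a limit.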

Compound 4, a percentage reported as inhibition, at one concentration (the size of the read-out at that concentration, not a potency): < 5%
Compound 4: a limit, no number (the forecaster's own chance of this, stated with the estimate: 80%); the middle value is on the limit's open side.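

Within the data shown here, compound 4 is reported only as a limit in this assay, just as compound 1 is, so no step between them can be read: the limit of < 5% in this assay, at which 4 of the 4 values shown sit. The compounds shown leave open whether any change to the shared core gives inhibition that can be read as a number.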